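Aryl versus alkyl on the ring nitrogen: compound 4

The source may hold more compounds than are shown below. What is called first, only, known or untested is meant among the compounds shown, and "the series" means these compounds.

Compound 3 `O=C(CN1CCN(c2ccc([N+](=O)[O-])cc2)CC1)Nc1nc2ccccc2[nH]1` gives 64.9% in a functional assay, read by spectrophotometry, with a stated time of 30 min, tested at 150 ug/mL (a higher number here means a stronger effect of the compound at the concentration tested, a lower number a weaker effect), the highest of the three numbers. Compound 1 `CCN1CCN(CC(=O)Nc2nc3ccccc3[nH]2)CC1` gives 57.5%, and a number 7.4 percentage points higher from compound 1 to compound 3 (within the scatter). Compound 2 `COc1ccc(N2CCN(CC(=O)Nc3nc4ccccc4[nH]3)CC2)cc1` gives 53.2%, and a number 11.7 percentage points higher from compound 2 to compound 3 (beyond the scatter). Compound 4 `COc1ccccc1N1CCN(CC(=O)Nc2nc3ccccc3[nH]2)CC1` is not yet measured; it differs from compound 3 by 2-methoxyphenyl in place of 4-nitrophenyl on an amine nitrogen in a ring. The step of a number 11.7 percentage points higher from compound 2 to compound 3 (beyond the scatter) bears on this change, since compound 4 again carries a methoxy group in place of the nitro group, and a number 4.3 percentage points lower from compound 1 to compound 2 (within the scatter) shows that a methoxyphenyl and an ethyl sit close together. Going by the values given here, no measured compound carries a 2-methoxyphenyl. A downward step of modest size is therefore expected, a number 10.9 percentage points lower from compound 3 to compound 4 (beyond the scatter), with compound 4 estimated at 54%, ranging from 42% to 66%.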

Compound 4, a percentage reported as activity, at one concentration (the size of the read-out at that concentration, not a potency): 55.2%
The estimate for compound 4 lay 1.2 percentage points below the measured number; low and high end bracket the measured number.
By their numbers in this assay, from the lowest: compounds 2, 4, 1 and 3 (each within the scatter of the next, the first and the last beyond it).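

In this assay, the 2-methoxyphenyl and the 4-methoxyphenyl read alike (a number 2 percentage points higher from compound 2 to compound 4 (within the scatter)), and the 2-methoxyphenyl also stays within the scatter of ethyl on the same ring nitrogen (a number 2.3 percentage points lower from compound 1 to compound 4 (within the scatter)). Unlike the 4-methoxyphenyl, the 2-methoxyphenyl also stays within the scatter of the 4-nitrophenyl (a number 9.7 percentage points lower from compound 3 to compound 4 (within the scatter)), so only the step from compound 2 to compound 3 separates any of these groups. Nothing measured here accounts for these steps. Still open, going by these compounds, is how an amine or a carboxylic acid on the phenyl ring would read, and how a longer chain in place of ethyl would compare with compound 1.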